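Pyridin-2-yl for tert-butyl on a pyrazolopyridinone pair

A few compounds are considered here, and "the series" means these few. Any claim that something is new, unique, unknown or untested is made for them only; others in the source may bear on it.

Of the compounds shown here, two of a shared core have been tested in an assay on isolated protein for inhibition of protein kinase C zeta type (Homo sapiens), read by mobility shift assay, tested at 30 uM; on this read-out lower numbers stand for less inhibition and higher numbers for more inhibition at the one concentration tested (going by the name of the read-out). Compound 1 `Cc1cc2c(c(N)nn2C)c(=O)[nH]1` gives 0% in this assay. Compound 2 `CC(C)(C)c1cc2nn(-c3ccccc3)c(N)c2c(=O)[nH]1` gives -1% in this assay, the lowest of the two numbers, with compound 1 as its nearest neighbour at a gap that lies within the scatter. Neither compound therefore shows inhibition beyond the noise at the concentration tested.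

Compound 3 `Nc1c2c(=O)[nH]c(-c3ccccn3)cc2nn1-c1ccccc1` has not yet been measured in this assay. It differs from compound 2 in one place: pyridin-2-yl in place of tert-butyl on an aromatic carbon. Among the compounds with values here, no step between measured compounds is available to gauge such a change. Given that compound 2 gives -1% and that compound 1 gives no more, compound 3 is expected to show a step of a number 5 percentage points higher from compound 2 to compound 3 (within the scatter) that does not exceed the scatter. Compound 3 is therefore estimated at 4%, in a range from -10% to 22%.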

Compound 3, a percentage reported as inhibition, at one concentration (the size of the read-out at that concentration, not a potency): 3%
For compound 3 the middle estimate is 1 percentage points above the measured one; low and high end bracket the measured number.
By their numbers in this assay, from the lowest: compounds 2, 1 and 3 (each within the scatter of the next).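

In this assay, pyridin-2-yl in place of tert-butyl on the aromatic carbon next to the ring nitrogen gives a number 4 percentage points higher from compound 2 to compound 3 (within the scatter). This position therefore accepts a six-membered aromatic ring with 1 hetero atom in place of tert-butyl, yet the exchange brings no inhibition beyond the noise at the one concentration tested. Nothing shown offers an explanation for this flat result.

From the compounds shown here alone, whether any other group at this position, such as an amine, a carboxylic acid or a longer chain, would produce a step beyond the scatter remains open. The compounds shown also leave open whether a methoxy group or a halogen on the pyridin-2-yl ring would change the reading in this assay.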